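Extending the Alkoxy Group on the Chloro Analogue

The source may hold more compounds than are shown below. What is called first, only, known or untested is meant among the compounds shown, and "the series" means these compounds.

Compound 2 `COc1cc2[nH]c(Cc3nn(CC(=O)O)c(=O)c4ccccc34)nc2cc1Cl` gives 61 nM in a functional assay on CHO cells for antagonist activity at sphingosine 1-phosphate receptor 2 (Homo sapiens), read by calcium flux (on this read-out higher numbers stand for weaker inhibition and lower numbers for stronger inhibition), the higher of the two numbers recorded so far. Compound 1 `O=C(O)Cn1nc(Cc2nc3cc(F)c(OCC4CC4)cc3[nH]2)c2ccccc2c1=O` gives 18 nM in this assay. Among the compounds with values here, compound 3 `O=C(O)Cn1nc(Cc2nc3cc(Cl)c(OCC4CC4)cc3[nH]2)c2ccccc2c1=O` differs from compound 2 by cyclopropyl in place of hydrogen on a saturated chain carbon bound to an oxygen on an aromatic ring; no such single step has been measured between two compounds here. Because compound 1, which carries the same cyclopropylmethoxy group, gives 18 nM, the step from compound 2 to compound 3 is expected to lower the number beyond the scatter, a 2.4-fold lower number from compound 2 to compound 3 (0.39 log units; beyond the scatter). Compound 3 is estimated at 25 nM, with a range from 8 nM to 75 nM.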

Compound 3, half-maximal inhibitory concentration: 8.8 nM
The estimate for compound 3 lay 2.8-fold (0.45 log units) above the measured number; the measured number falls inside the stated range.
By their numbers in this assay, from the lowest: compound 3; then compound 1; then compound 2.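

Methoxy to cyclopropylmethoxy, now read directly on the chloro compounds, gives a 6.9-fold lower number from compound 2 to compound 3 (0.84 log units; beyond the scatter) in this assay. With cyclopropylmethoxy held fixed, chloro in place of fluoro on an aromatic carbon gives a 2.0-fold lower number from compound 1 to compound 3 (0.31 log units; beyond the scatter), a smaller step that still lies beyond the scatter. Nothing available here accounts for either step.

Going by these compounds, whether cyclobutyl or a longer chain in place of cyclopropyl would lower the number further stays open. So does how the fluoro counterpart carrying methoxy would compare with compound 2.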